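This account rests on a few compounds, and the source may have more. Where it says the series, first, only, none or still open, it means among the compounds named here.

Compound 1, `O=C(CSc1nc(Nc2ccccc2)c2ccccc2n1)Nc1ccccc1F`, measured in a functional assay on MDA-MB-231 cells (Homo sapiens) for inhibition, read by MTT assay, with a stated time of 72 h; on this read-out lower numbers stand for stronger inhibition and higher numbers for weaker inhibition: > 50000 nM, a limit of the assay rather than a number.
Compound 2, `CCc1cccc(NC(=O)CSc2nc(Nc3ccccc3)c3ccccc3n2)c1`: 12400 nM.
Compound 3, `C=CC(=O)Nc1cccc(NC(=O)CSc2nc(Nc3cccc(Cl)c3)c3ccccc3n2)c1`: 16300 nM.

Compound 3 and compound 2 lie within the usual scatter of each other, so the two numbers cannot be told apart. Compound 1 sits at the limit of > 50000 nM in this assay, at which 1 of the 3 values shown sits.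

Compound 4, `C=CC(=O)Nc1cccc(NC(=O)CSc2nc(Nc3ccc(Cl)c(Cl)c3)c3ccccc3n2)c1`, has not yet been measured in this assay. It differs from compound 3 in one place: chloro in place of hydrogen on an aromatic carbon. The change therefore falls on the ring attached to the shared core through the amino group, not on the ring attached to the amide-type nitrogen.

For the measured compounds named here, the only measured step, an at least 4.0-fold lower number from compound 1 to compound 2 (0.60 log units; beyond the scatter), exchanges the aryl group on the amide-type nitrogen. Going by the values given here, it says nothing about the ring that carries the chloro group, so no measured step bears on the change from compound 3 to compound 4. With no guidance either way, the expectation is a step no larger than the scatter: a 1.1-fold lower number from compound 3 to compound 4 (0.04 log units; within the scatter). Compound 4 is therefore estimated at 15000 nM, with a range from 6000 nM to 40000 nM.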

Compound 4, half-maximal inhibitory concentration: 17700 nM
Beside the measured number, compound 4's estimate is 1.2-fold (0.07 log units) below it, and the stated range covers the measured number.
By their numbers in this assay, from the lowest: compounds 2, 3 and 4 (each within the scatter of the next). At a limit, above all of these: compound 1.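

For the compounds shown here, compound 4 gives the first measured step on the ring attached to the shared core through the amino group: in this assay, going from 3-chlorophenyl to 3,4-dichlorophenyl gives a 1.1-fold higher number from compound 3 to compound 4 (0.04 log units; within the scatter), and the two numbers cannot be told apart. The earlier step concerned only the aryl group on the amide-type nitrogen, whereas this one shows that, for this pair, a second chloro on an aromatic carbon, ortho to the first chloro group and para to a large group, leaves compound 4 indistinguishable from compound 3. No measurement shown gives a reason for this result.

Going by these compounds alone, a single chloro speaks for only one small group at this carbon, and whether a methoxy group, an amine or a carboxylic acid there would give a step beyond the usual scatter remains open. Also open, going by these compounds, is what the first chloro contributes on its own: compound 2 and compound 3 differ in more than one place, and their numbers cannot assign an effect to that group.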